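The source may hold more compounds than are shown below. What is called first, only, known or untested is meant among the compounds shown, and "the series" means these compounds.

Of the compounds shown here, three from this series have been tested in a functional assay on HepG2 cells (Homo sapiens) for inhibition, read by MTT assay, with a stated time of 48 h; on this read-out lower numbers stand for stronger inhibition and higher numbers for weaker inhibition. Compound 1, with the structure `COc1ccccc1-c1csc(N/N=C/c2cc(OC)c(OC)c(Br)c2Br)n1`, gives > 100000 nM in this assay, and this is a limit of the assay rather than a number. Compound 3, with the structure `COc1cc(/C=N/Nc2nc(-c3cc(C(F)(F)F)cc(C(F)(F)F)c3)cs2)c(Br)c(Br)c1OC`, likewise gives > 100000 nM in this assay, again a limit rather than a number. Compound 2, with the structure `Fc1ccc(/C=N/Nc2nc(-c3ccc(C(F)(F)F)cc3)cs2)cc1F`, is the only one of the three for which this assay returns a real number, namely 14500 nM. Compound 2 therefore stands alone among the values shown, while the other two results sit at the limit of > 100000 nM in this assay, at which 2 of the 3 values shown sit.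

The next compound, compound 4, has the structure `Fc1ccc(/C=N/Nc2nc(-c3ccc(Br)cc3)cs2)cc1F`. It differs from compound 2 in a single place: bromo in place of trifluoromethyl on an aromatic carbon. Within the data shown here, no pair of measured compounds in this set differs by such a change, so there is no measured step to lean on, and the expectation rests on compound 2 alone. The expected step from compound 2 to compound 4, a 1.0-fold higher number from compound 2 to compound 4 (0.01 log units; within the scatter), is estimated to stay within the usual scatter of this assay, with no clear direction. Compound 4 is accordingly expected to give about 15000 nM in this assay, with an estimated range from 6000 nM to 40000 nM.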

Compound 4, half-maximal inhibitory concentration: > 100000 nM
Compound 4 was reported as a limit (the forecaster's own chance of this, stated with the estimate: 10%); middle value at least 6.6-fold (0.82 log units) away from the limit.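

In this assay, among these compounds, putting bromo in place of trifluoromethyl on an aromatic carbon gives an at least 6.8-fold higher number from compound 2 to compound 4 (0.83 log units; beyond the scatter), the first comparison in this set between two compounds that differ in one place, and it shows that the group on this carbon, para to a large group, matters to the read-out. The result for compound 4, > 100000 nM, is a limit of the assay and not a number, so the step gives only the smallest size the change can have, not its true size. Among the compounds shown here, compound 2 therefore remains the only compound here with a real number, and compound 4 joins the other results at the limit: the limit of > 100000 nM in this assay, at which 3 of the 4 values shown sit.

These compounds do not show why the trifluoromethyl compound gives a number while the bromo compound does not, and compounds 1 and 3 differ from compound 2 in more than one place, so they cannot settle this. For the compounds shown here, it also remains open whether another group on this carbon, such as chloro, methoxy, an amine or a carboxylic acid, would give a real number, and how that number would compare with the one for compound 2.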